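The compounds below may be only part of what the source reports. "The series", "measured", "known", "first", "only" and "open" are said of these compounds alone.

Measured so far:

- compound 1, `CCC(=O)[C@H]1O[C@@H](n2cnc3c(N)nc(C#Cc4ccccc4)nc32)[C@H](O)[C@@H]1O`, gives 7.3 nM in an assay on CHO cells for displacement of a labelled ligand from adenosine receptor A3 (Homo sapiens); on this read-out higher numbers stand for weaker inhibition and lower numbers for stronger inhibition
- compound 2, `CONc1nc(C#Cc2ccccn2)nc2c1ncn2[C@@H]1O[C@H](CO)[C@@H](O)[C@H]1O`, gives 2.3 nM in this assay

Of the two numbers, compound 2 stands lowest; the nearest is compound 1, whose number is higher by a gap that lies beyond the usual scatter. Compound 2 therefore shows the stronger inhibition of the pair.

Compound 3, `C#Cc1nc(NOC)c2ncn([C@@H]3O[C@H](CO)[C@@H](O)[C@H]3O)c2n1`, is the next step and has not yet been measured in this assay. It differs from compound 2 in one place: hydrogen in place of pyridin-2-yl on a triple-bonded carbon. Put another way, the group that reaches out from the shared core on a two-carbon triple bond is cut back, and the triple bond ends in a bare hydrogen.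

Among the compounds with values here, no measured pair shows this particular change, so the size of the step cannot be read from the data. A piece that is lost here is the larger part of what sits on the triple bond, and the expectation is that compound 3 gives a higher number than compound 2, a weakening of inhibition that goes beyond the scatter, with the step from compound 2 to compound 3 estimated at a 13-fold higher number from compound 2 to compound 3 (1.12 log units; beyond the scatter). Compound 3 is thus expected to give about 30 nM, within a range from 8 nM to 150 nM.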

Compound 3, inhibition constant: 23 nM
For compound 3 the middle estimate is 1.3-fold (0.12 log units) above the measured one; measured number inside the range.
By their numbers in this assay, from the lowest: compound 2; then compound 1; then compound 3.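

In this assay, replacing pyridin-2-yl on the triple-bonded carbon with hydrogen gives a 10-fold higher number from compound 2 to compound 3 (1.00 log units; beyond the scatter) and this step lies beyond the scatter, so the group at the end of the triple bond clearly matters for inhibition when the rest of the molecule stays the same. The loss is not complete, though: compound 3, with only an ethynyl group left on the shared core, still gives 23 nM in this assay and so keeps a good part of its inhibition without the ring. No measurement here explains why the step has this size.

The compounds shown cannot separate what the ring as a whole contributes from what its nitrogen contributes, since a plain phenyl group or a pyridin-3-yl group on the triple bond of this same molecule would be needed for that comparison. They also leave open how a smaller piece, such as a methyl group, or a longer chain ending in an amine would fare on the same triple-bonded carbon, and whether such a group would fall nearer compound 2 or compound 3.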